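The source may hold more compounds than are shown below. What is called first, only, known or untested is meant among the compounds shown, and "the series" means these compounds.

Of the compounds shown here, three built on one shared core have been tested in a functional assay on A498 cells (Homo sapiens) for inhibition, read by sulforhodamine B assay, with a stated time of 48 h, tested at 10 uM; a lower number here means a stronger effect, a higher number a weaker effect of the compound at the concentration tested. Compound 1 `COc1cc(Cl)cc(-c2nn(-c3cccc(NC(=O)Nc4ccc(Cl)c(Cl)c4)c3)cc2-c2ccncc2)c1` gives -9.54% in this assay. Compound 2 `COc1cc(Cl)cc(-c2nn(-c3cccc(NC(=O)c4cccc(C(F)(F)F)c4)c3)cc2-c2ccncc2)c1` gives 21.2% in this assay. Among the compounds with values here, the only step between measured compounds that differ in a single place is a number 30.7 percentage points higher from compound 1 to compound 2 (beyond the scatter). Compound 3 `O=C(Nc1cccc(-n2cc(-c3ccncc3)c(-c3cc(O)cc(Cl)c3)n2)c1)c1cc(C(F)(F)F)cc(C(F)(F)F)c1` gives 40.3% in this assay, the highest of the three numbers and so the weakest effect at the tested concentration; it stands beyond the scatter from compound 2 and further still from compound 1.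

Compound 4 `COc1cc(Cl)cc(-c2nn(-c3cccc(NC(=O)c4cc(C(F)(F)F)cc(C(F)(F)F)c4)c3)cc2-c2ccncc2)c1` has not yet been measured. It differs from compound 3 by methyl in place of hydrogen on an oxygen on an aromatic ring. Within the data shown here, no measured step concerns this oxygen: the single known step sits at the carbonyl carbon, a different place. Compounds 1 and 2 carry the methoxy group and compound 3 the hydroxy group, but compound 3 also differs from both at the carbonyl carbon, so their values give no clean reading of the oxygen alone. With nothing to build on, the expected step is a number 2.3 percentage points lower from compound 3 to compound 4 (within the scatter), within the scatter. Compound 4 is therefore estimated at 38%, with a range from 18% to 58%.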

Compound 4, a percentage reported as activity, at one concentration (the size of the read-out at that concentration, not a potency): -1.74%
Estimate against measurement, compound 4: 39.7 percentage points above; measured number below the stated range.
By their numbers in this assay, from the lowest: compounds 1 and 4 (each within the scatter of the next); then compound 2; then compound 3.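

Capping the hydroxy oxygen with a methyl group turns out to matter a great deal: in this assay, the change from hydroxy to methoxy gives a number 42 percentage points lower from compound 3 to compound 4 (beyond the scatter), and since a lower number means a stronger effect, this position clearly responds to a single added carbon. The group on the carbonyl carbon also proves sensitive to a small edit. Trifluoromethyl in place of hydrogen on an aromatic carbon gives a number 22.9 percentage points lower from compound 2 to compound 4 (beyond the scatter), showing that this part of the molecule can shift the read-out even when the methoxy group stays fixed. Nothing measured in these data explains why either change alters the read-out.

As far as these compounds go, the hydroxy-to-methoxy step rests on one pair of compounds, so it remains open whether it would hold with a different group on the carbonyl carbon, such as the urea-linked 3,4-dichlorophenyl group of compound 1. The compounds shown also carry only hydrogen or methyl on this oxygen, which leaves open how an ethyl group, a longer chain or a chain ending in an amine would behave there.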